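This account rests on a few compounds, and the source may have more. Where it says the series, first, only, none or still open, it means among the compounds named here.

Compound 1 `CC1=C(O)[C@@H](C/C(C)=C\CCC(C)/C=C/C=C(\C)CCCc2ccoc2)OC1=O` and compound 2 `CC1=C(O)/C(=C\[C@H](C)CCC/C(C)=C/CCc2coc(Cc3ccoc3)c2)OC1=O` share one core and differ in the chain attached to it. In a functional assay on XF498 cells (Homo sapiens) for cytotoxicity (a higher number here means that more compound is needed for the effect, a lower number that less compound is needed), compound 1 gives 24.8 ug/mL and compound 2 gives 6.52 ug/mL, the lower of the two numbers, with a gap beyond the usual scatter. Compound 3 `CC1=C(O)/C(=C/[C@H](C)CCC/C(C)=C/CCc2coc(Cc3ccoc3)c2)OC1=O` is the next step from compound 2: the two compounds have the same atoms and bonds and differ only in configuration as drawn: 1 of 3 stereo elements differ; a double bond is drawn E in compound 2 and Z in compound 3. For the measured compounds named here, no measured pair shows what a change of double-bond configuration alone does in this assay, so the step of a 1.2-fold higher number from compound 2 to compound 3 (0.09 log units; within the scatter) is expected to be modest, without a firm direction. Compound 3 is expected to give 8 ug/mL, with a range from 3 ug/mL to 22 ug/mL.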

Compound 3, concentration for half-maximal effect: 5.42 ug/mL
Beside the measured number, compound 3's estimate is 1.5-fold (0.17 log units) above it; the measured number falls inside the stated range.
By their numbers in this assay, from the lowest: compounds 3 and 2 (each within the scatter of the next); then compound 1.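

For the compounds shown here, this is the first pair to isolate double-bond configuration, and in this assay the change from E to Z gives a 1.2-fold lower number from compound 2 to compound 3 (0.08 log units; within the scatter). At this double bond, therefore, the two drawn forms cannot be told apart in this assay. The comparison bears on configuration alone: the fact that compounds 2 and 3 differ only in the configuration as drawn

From the compounds shown here alone, whether the configuration of this double bond would matter as little on a longer chain, or on a chain carrying an amine or a carboxylic acid, remains open. The pair also cannot show whether this result extends to other cell lines.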